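This account rests on a few compounds, and the source may have more. Where it says the series, first, only, none or still open, it means among the compounds named here.

Measured so far:
compound 1, `Cn1c(=O)c(S(=O)(=O)c2ccc(O)cc2)cc2cnc(Nc3ccc4[nH]ccc4c3)nc21`: 250 nM
compound 2, `Cc1ccc(S(=O)(=O)c2cc3cnc(Nc4cnc5[nH]ccc5c4)nc3n(C)c2=O)cc1`: 25000 nM
compound 3, `COC(=O)Cn1ccc2cc(Nc3ncc4cc(S(=O)(=O)c5ccc(F)cc5F)c(=O)n(C)c4n3)ccc21`: 5000 nM

All three were tested in a functional assay on DU-145 cells (Homo sapiens) for inhibition, read by trypan blue exclusion, with a stated time of 72 h; on this read-out higher numbers stand for weaker inhibition and lower numbers for stronger inhibition. On these numbers compound 1 stands lowest, meaning the strongest inhibition of the three. The nearest to it is compound 3, whose number is higher by a gap beyond the usual scatter, and the furthest is compound 2, higher still. Compound 2 and compound 3 each differ from compound 1 in more than one place, so neither pairing isolates a single change.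

The compound now in question is compound 4, `Cn1c(=O)c(S(=O)(=O)c2ccc(Br)cc2)cc2cnc(Nc3ccc4[nH]ccc4c3)nc21`. It keeps the shared core of compound 1 and differs from it in one place: bromo in place of hydroxy on an aromatic carbon

Among the measured compounds shown here, no pair of measured compounds shows this exact exchange, so its effect in this assay cannot be read off directly. The hydroxy of compound 1 carries the only hydrogen-bond donor that leaves in this step, and a small to moderate loss of inhibition, that is a higher number, seems the more likely outcome, though a result within the scatter cannot be ruled out. The expected step from compound 1 to compound 4 is therefore a 4.8-fold higher number from compound 1 to compound 4 (0.68 log units; beyond the scatter). Compound 4 is estimated at 1200 nM, with a likely range from 250 nM to 6000 nM.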

Compound 4, half-maximal inhibitory concentration: 5000 nM
Compound 4: middle estimate off by 4.2-fold (0.62 log units), on the low side; measured number inside the range.
By their numbers in this assay, from the lowest: compound 1; then compounds 3 and 4 (each within the scatter of the next); then compound 2.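

In this assay, putting 4-bromophenyl in place of 4-hydroxyphenyl on the sulfonyl group gives a 20-fold higher number from compound 1 to compound 4 (1.30 log units; beyond the scatter), which is large. Among the compounds shown here, this is the first step in the set where everything else in the molecule stays the same, so the loss of inhibition can be assigned to this one exchange, something the earlier compounds, which differ in more than one place, could not show. No measurement shown here explains the step, and the hydrogen-bond donor that leaves with the hydroxy is only one of the ways in which the two groups differ.

As far as these compounds go, with only hydroxy and bromo to compare at this place, it remains open whether hydroxy is especially favourable or bromo especially unfavourable, and a methoxy group, an amine or plain hydrogen there would help to tell these apart. For the compounds shown here, it also remains open whether the same exchange would produce a step of similar size if the group attached through the amine nitrogen were different from the one in compound 1.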